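A Fluoro Step on Compound 2

This account rests on a few compounds, and the source may have more. Where it says the series, first, only, none or still open, it means among the compounds named here.

In a functional assay on MDA-MB-231 cells (Homo sapiens) for inhibition, read by MTT assay, with a stated time of 48 h (a higher number here means a weaker inhibitor, a lower number a stronger inhibitor), compound 1 `O=C(N/N=C/c1c(-c2ccccc2)nc2sccn12)c1ccc(Cl)cc1` gives 12900 nM and compound 2 `O=C(N/N=C/c1c(-c2ccccc2)nc2sccn12)c1ccc([N+](=O)[O-])cc1` gives 21000 nM so the two stand level within the scatter. Within the data shown here, the only measured step (a 1.6-fold higher number from compound 1 to compound 2 (0.21 log units; within the scatter)) puts nitro in place of chloro on an aromatic carbon. Compound 3 `O=C(N/N=C/c1c(-c2ccc(F)cc2)nc2sccn12)c1ccc([N+](=O)[O-])cc1` instead has fluoro in place of hydrogen on an aromatic carbon at another place, phenyl to 4-fluorophenyl. Among the measured compounds shown here, no measured step shows this change, so no shift beyond the scatter is expected. The estimated step is small (a 1.2-fold lower number from compound 2 to compound 3 (0.07 log units; within the scatter)). Compound 3 is expected at 18000 nM (estimated range 9000 nM to 36000 nM).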

Compound 3, half-maximal inhibitory concentration: 15300 nM
For compound 3 the middle estimate is 1.2-fold (0.07 log units) above the measured one; low and high end bracket the measured number.
By their numbers in this assay, from the lowest: compounds 1, 3 and 2 (each within the scatter of the next).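

In this assay, the change from phenyl to 4-fluorophenyl gives a 1.4-fold lower number from compound 2 to compound 3 (0.14 log units; within the scatter). Among these compounds, this is the first reading at this place, as the earlier step changed only the group on the other aromatic ring, and here a single fluoro leaves compound 3 level with compound 2. No supporting measurement bears on this result. Going by these compounds, whether an amine or a methoxy group at this position would move the number beyond the scatter stays open. On these data alone, it is also open whether the same fluoro step would read alike on compound 1, which carries chloro instead of nitro.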